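The compounds below may be only part of what the source reports. "The series", "measured", "known", "first", "only" and "open" are said of these compounds alone.

Measured compounds in a functional assay on NFS-60 cells (Mus musculus) for inhibition, with a stated time of 72 h; on this read-out lower numbers stand for stronger inhibition of growth and higher numbers for weaker inhibition of growth:
- compound 1 `Nc1ncnc2c(C(=O)Nc3cccc4c3c(Br)nn4Cc3ccccc3)csc12`: 1010 nM
- compound 2 `COc1ccc(Cn2nc(Br)c3c(NC(=O)c4csc5c(N)ncnc45)cccc32)cc1`: 2390 nM
- compound 3 `Nc1ncnc2c(C(=O)Nc3cccc4c3c(Br)nn4Cc3ccncc3)csc12`: 135 nM

Compound 1 gives the second highest number of the three in this assay; compound 2 sits nearest, with a 2.4-fold higher number from compound 1 to compound 2 (0.37 log units; beyond the scatter), and compound 3 furthest, with a 7.5-fold lower number from compound 1 to compound 3 (0.87 log units; beyond the scatter). Compound 4 `CCn1nc(Cn2nc(Br)c3c(NC(=O)c4csc5c(N)ncnc45)cccc32)cc1C(C)C` is not yet measured. It differs from compound 1 by 1-ethyl-5-isopropyl-1H-pyrazol-3-yl in place of phenyl on a saturated chain carbon bound to an aromatic nitrogen. Among the measured compounds shown here, the steps that bear on this are those that also replace the phenyl on the saturated chain carbon bound to an aromatic nitrogen: a 7.5-fold lower number from compound 1 to compound 3 (0.87 log units; beyond the scatter) and an 18-fold lower number from compound 2 to compound 3 (1.25 log units; beyond the scatter), both toward lower numbers when a nitrogen-containing aromatic ring enters there. A pyrazole bearing ethyl and isopropyl is a larger change, so a smaller gain is expected; the estimated step is a 2.0-fold lower number from compound 1 to compound 4 (0.31 log units; beyond the scatter). Compound 4 is therefore expected to give about 500 nM, between 120 nM and 2000 nM.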

Compound 4, concentration for 50% growth inhibition: 62 nM
Estimate against measurement, compound 4: 8.1-fold (0.91 log units) above; measured number below the stated range.
By their numbers in this assay, from the lowest: compound 4; then compound 3; then compound 1; then compound 2.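

In this assay a group with more heavy atoms than phenyl is tolerated on the saturated chain carbon bound to an aromatic nitrogen, with a 16-fold lower number from compound 1 to compound 4 (1.21 log units; beyond the scatter) and a 39-fold lower number from compound 2 to compound 4 (1.59 log units; beyond the scatter) when 1-ethyl-5-isopropyl-1H-pyrazol-3-yl enters. This group also goes past pyridin-4-yl, with a 2.2-fold lower number from compound 3 to compound 4 (0.34 log units; beyond the scatter) so pyridin-4-yl is not the only ring here that lowers the number. Nothing available explains this gain.

Still open, going by these compounds, is whether the ring, the ethyl or the isopropyl carries the gain, since these three parts always appear together here. Also open, on these data alone, is how a morpholine or a carboxylic acid would behave at this place.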